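The source may report more compounds than this note shows. Statements on the series, on what has been measured and on what is new or still open speak of the compounds shown alone.

Of the compounds shown here, three built on a shared core have been measured in an assay on VSM-A10 cells for antagonist activity at Endothelin-1 receptor (Rattus norvegicus); a lower number here means a stronger inhibitor, a higher number a weaker inhibitor. Compound 1 `Cc1noc(NS(=O)(=O)c2cccc3c(NC(=O)C(C)C)cccc23)c1C` gives 880 nM. Compound 2 `Cc1noc(NS(=O)(=O)c2ccc(F)cc2)c1C` gives 1000 nM, the second highest of the three numbers; its nearest neighbour is compound 1, which sits within the usual scatter of it, so the two cannot be told apart. The furthest is compound 3 `CCOC(=O)c1c(C)noc1NS(=O)(=O)c1cccc2c(N(C)C)cccc12`, which in this assay gives 31000 nM, a gap well beyond the scatter.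

Compound 4 `Cc1noc(NS(=O)(=O)c2ccc(NC(=O)CN)cc2)c1C` has not yet been measured. It differs from compound 2 in one place: ((aminomethyl)carbonyl)amino in place of fluoro on an aromatic carbon, on an aromatic carbon of a six-membered aromatic ring of carbon only, para to a large group. Among the compounds with values here, no pair of measured compounds differs in just this way, so the step has to be judged indirectly. The nearest hint is compound 1, which also carries an amide-linked substituent and gives 880 nM, close to compound 2. The expected step is small, a 1.5-fold higher number from compound 2 to compound 4 (0.18 log units; within the scatter), with no clear direction beyond the scatter. Compound 4 is estimated at 1500 nM, within 300 nM to 8000 nM.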

Compound 4, half-maximal inhibitory concentration: 6500 nM
The estimate for compound 4 lay 4.3-fold (0.64 log units) below the measured number, and the stated range covers the measured number.
By their numbers in this assay, from the lowest: compounds 1 and 2 (each within the scatter of the next); then compound 4; then compound 3.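

In this assay, this position on the six-membered aromatic ring proves sensitive to what it carries: ((aminomethyl)carbonyl)amino in place of fluoro gives a 6.5-fold higher number from compound 2 to compound 4 (0.81 log units; beyond the scatter) and so a modest but real weakening. Within the data shown here, this is the first step between measured compounds that differ in one place, and it shows that replacing a single fluorine atom with a group of 5 heavy atoms, bearing hydrogen-bond donors and acceptors, does not leave the number unchanged. Nothing measured here says why the number rises.

From the compounds shown here alone, whether the loss follows the amide link or the terminal amine stays open, and a plain acetyl amide on the same aromatic carbon would separate the two. A simple amine or a longer chain there would show how far the trend extends.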